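Swapping an aryl group for isobutyl on a shared core

The compounds below may be only part of what the source reports. "The series", "measured", "known", "first", "only" and "open" are said of these compounds alone.

Of the compounds shown here, three of one series have been measured in a physicochemical assay for acid dissociation: compound 1 `COc1cccc(CNCCCNc2ccnc3cc(Oc4ccc(Cl)cc4)ccc23)c1O` gives 9.28, compound 2 `COc1cccc(CNCCCNc2ccnc3cc(Oc4cccc(N(C)C)c4)ccc23)c1O` gives 9.28, and compound 3 `COc1cccc(CNCCCNc2ccnc3cc(-c4ccc(F)cc4)ccc23)c1O` gives 9.47. Compound 3 stands at the top of these three numbers, but only just: the step of a number 0.19 log units higher from compound 1 to compound 3 (within the scatter) and the step of a number 0.19 log units higher from compound 2 to compound 3 (within the scatter) are both within the scatter, as is the step of no change at the digits printed from compound 1 to compound 2 (within the scatter), so the three compounds cannot be told apart on this read-out.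

Compound 4 `COc1cccc(CNCCCNc2ccnc3cc(CC(C)C)ccc23)c1O` has not yet been measured. It differs from compound 3 in one place: isobutyl in place of 4-fluorophenyl on an aromatic carbon. The change sits on the same aromatic carbon that was altered in the two steps leading to compound 3, and each of those steps moved the value by no more than the scatter. Every measured change at that position has left this assay unmoved, so the expectation for compound 4 is a step of a number 0.07 log units lower from compound 3 to compound 4 (within the scatter), no larger than the scatter, in no definite direction. Compound 4 is therefore estimated at 9.4, with a range from 9.1 to 9.7.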

Compound 4, acid dissociation constant: 9.47
Estimate against measurement, compound 4: 0.07 log units below; the range from low to high includes it.
By their numbers in this assay, from the lowest: compounds 1, 2, 3 and 4 (each within the scatter of the next).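

Until now, every group on this aromatic carbon carried an aromatic ring, either directly or through an oxygen, whereas the isobutyl of compound 4 has no ring and fewer heavy atoms than the 4-fluorophenyl it replaces. Even so, this assay shows no change at the digits printed from compound 3 to compound 4 (within the scatter) for this change. Set against the two compounds with an oxygen-linked ring, the picture is the same, with a number 0.19 log units higher from compound 2 to compound 4 (within the scatter) and a number 0.19 log units higher from compound 1 to compound 4 (within the scatter) in this assay, so an aromatic ring at this position is not needed to keep the number within the scatter of the other three compounds.

Still open, from the compounds shown here alone, is whether a group of another kind on this same aromatic carbon, such as an amine or a carboxylic acid, would also leave this assay within the scatter of these four compounds. No supporting information is available to explain why the aryl, aryloxy and isobutyl groups cannot be told apart on this read-out.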